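A few compounds are considered here, and "the series" means these few. Any claim that something is new, unique, unknown or untested is made for them only; others in the source may bear on it.

In a functional assay on MDA-MB-231 cells (Homo sapiens) for inhibition, read by MTT assay, with a stated time of 72 h (a higher number here means a weaker inhibitor, a lower number a stronger inhibitor), compound 3 (`O=C(NO)c1ccc(CNCc2nc(-c3ccc(Cl)cc3)no2)cc1`) gives 10900 nM and sits within the scatter of compound 2 (`O=C(NO)c1ccc(CNCc2nc(-c3ccc(C(F)(F)F)cc3)no2)cc1`), which gives 12300 nM here. Compound 1 (`Nc1ccccc1NC(=O)c1ccc(CNCc2nc(-c3ccc(F)cc3)no2)cc1`) reads 2950 nM in this assay and so shows a clearly lower number than compound 3.

The next change leads to compound 4 (`O=C(NO)c1ccc(CNCc2nc(-c3ccc(F)cc3)no2)cc1`): fluoro in place of chloro on an aromatic carbon, para to a large group (fluoro in place of chloro on an aromatic carbon). Among the compounds with values here, the only measured step of a similar kind is a 1.1-fold lower number from compound 2 to compound 3 (0.05 log units; within the scatter) (chloro in place of trifluoromethyl), and it stays within the scatter. Compound 1 already carries the 4-fluorophenyl group but also differs from compound 4 elsewhere, so it gives no direct reading of this change. One step is thin evidence, yet on that basis no shift beyond the scatter is expected in this assay in either direction. The expected step is a 1.0-fold lower number from compound 3 to compound 4 (0.02 log units; within the scatter) (within the scatter). Compound 4 is expected at 10500 nM (estimated range 5500 nM to 20000 nM).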

Compound 4, half-maximal inhibitory concentration: 9120 nM
Beside the measured number, compound 4's estimate is 1.2-fold (0.06 log units) above it, and the stated range covers the measured number.
By their numbers in this assay, from the lowest: compound 1; then compounds 4, 3 and 2 (each within the scatter of the next).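

Read in this assay the change from chloro to fluoro gives a 1.2-fold lower number from compound 3 to compound 4 (0.08 log units; within the scatter) and the change from trifluoromethyl to fluoro gives a 1.3-fold lower number from compound 2 to compound 4 (0.13 log units; within the scatter), so all three groups tested on this aromatic carbon, para to a large group, now stand within the scatter of one another. Within the data shown here, compound 4 also gives the first single-place comparison with the 2-aminophenyl amide, and hydroxy in place of 2-aminophenyl on the amide-type nitrogen gives a 3.1-fold higher number from compound 1 to compound 4 (0.49 log units; beyond the scatter), a modest step beyond the scatter. No measured evidence accounts for either reading.

From the compounds shown here alone, whether a methoxy group or an amine on this aromatic carbon would also stay within the scatter remains open. Also open, going by these compounds, is whether the 2-aminophenyl amide keeps its lower number with chloro or trifluoromethyl in place of fluoro.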